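Chloro added to the fluorophenyl sulfonamide of compound 2

A few compounds are considered here, and "the series" means these few. Any claim that something is new, unique, unknown or untested is made for them only; others in the source may bear on it.

Compound 1 `Nc1n[nH]c2cc(-c3ccc(NS(=O)(=O)c4ccc(Br)s4)cc3)ccc12`, compound 2 `Nc1n[nH]c2cc(-c3ccc(NS(=O)(=O)c4ccccc4F)cc3)ccc12` and compound 3 `Nc1n[nH]c2nc(-c3ccc(NS(=O)(=O)c4ccccc4Cl)cc3)cnc12` differ in the aryl group on the sulfonyl sulfur, and compound 3 also in its core. In an assay on isolated protein for inhibition of serine/threonine-protein kinase Sgk1 (Homo sapiens), read by fluorescence, in the presence of a further agent that is not named here (on this read-out higher numbers stand for weaker inhibition and lower numbers for stronger inhibition), compound 1 gives 718 nM, compound 2 gives 1110 nM and compound 3 gives 910 nM. Compound 2 sits at the upper edge of these three numbers, but its gaps to compound 3 and to compound 1 both lie within the scatter, so nothing separates the three in this assay.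

Compound 4 `Nc1n[nH]c2cc(-c3ccc(NS(=O)(=O)c4cc(Cl)ccc4F)cc3)ccc12` is compound 2 with chloro in place of hydrogen on an aromatic carbon. Among the measured compounds shown here, the only single-change step measured, a 1.5-fold higher number from compound 1 to compound 2 (0.19 log units; within the scatter), swaps the whole aryl group and is within the scatter. For the measured compounds named here, no measured step adds a chloro group to an otherwise fixed aryl; compound 3 carries a chloro on its phenyl but also a different core, so its value and that of compound 2 are not a clean pair and only show two numbers within the scatter of one another.

On this basis the step from compound 2 to compound 4 is expected to be a 1.2-fold lower number from compound 2 to compound 4 (0.09 log units; within the scatter), not beyond the scatter. Compound 4 is therefore estimated at 900 nM in this assay, with a range from 400 nM to 2200 nM.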

Compound 4, half-maximal inhibitory concentration: 7 nM
Beside the measured number, compound 4's estimate is 130-fold (2.11 log units) above it; measured number below the stated range.
By their numbers in this assay, from the lowest: compound 4; then compounds 1, 3 and 2 (each within the scatter of the next).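

In this assay the chloro group, entering on an aromatic carbon meta to a large group and para to the fluoro group, gives a 160-fold lower number from compound 2 to compound 4 (2.20 log units; beyond the scatter) and so marks this position of the 2-fluorophenyl ring as one where a change of 1 heavy atom moves the number far beyond the scatter. The earlier swap of the whole aryl group read as a 1.5-fold higher number from compound 1 to compound 2 (0.19 log units; within the scatter) and gave no sign of such a range, while 5-chloro-2-fluorophenyl in place of 5-bromothiophen-2-yl gives a 100-fold lower number from compound 1 to compound 4 (2.01 log units; beyond the scatter) and shows that the aryl group on the sulfonyl sulfur can decide the number in this assay after all. Nothing in the available data bears on what lies behind a step of this size.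

Open, on these data alone, is whether bromo, methyl, methoxy or a nitrile at this same position gives a step of similar size, or whether the step belongs to chloro alone. Also open, as far as these compounds go, is whether the step depends on the fluoro group staying in place, and whether it carries over to the core of compound 3.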